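A few compounds are considered here, and "the series" means these few. Any claim that something is new, unique, unknown or untested is made for them only; others in the source may bear on it.

Compound 1 `Cc1cc(C(=O)NCc2ccccc2)nn1Cc1cc(Cl)ccc1OCc1ccccc1`: > 3.7
Compound 2 `Cc1cc(C(N)=O)nn1Cc1cc(Cl)ccc1OCC(C)C`: 3.1
Compound 3 `Cc1cc(C(=O)NN2CCOCC2)nn1Cc1cc(Cl)ccc1OCC(C)C`: 3.1

Three compounds have results in a physicochemical assay for lipophilicity, at pH 7.4; on this read-out higher numbers stand for higher lipophilicity and lower numbers for lower lipophilicity. For compound 1 the result is not a number but a limit of the assay, > 3.7, so its true position is only known to lie beyond that point (the limit of > 3.7 in this assay, at which 1 of the 3 values shown sits). Compound 2 gives 3.1 in this assay. Compound 3 gives 3.1 in this assay. Going by the values given here, only one measured pair differs in a single place: no change at the digits printed from compound 2 to compound 3 (within the scatter), a change on an amide-type nitrogen that stays within the scatter.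

Compound 4 `Cc1cc(NC(=O)c2c(F)cccc2F)nn1Cc1cc(Cl)ccc1OCc1ccccc1` has not yet been measured. It differs from compound 1 in one place: ((2,6-difluorophenyl)carbonyl)amino in place of benzylcarbamoyl on an aromatic carbon. Among the compounds with values here, no measured step touches this part of the shared core, so the measured pair above gives no direct guide; the change swaps one aromatic amide for another of similar size, with two fluorine atoms entering.

Compound 4 is therefore expected to land near 4, estimated between 3.5 and 4.5. That estimate corresponds to a step that the limit leaves unreadable from compound 1 to compound 4, and it is expected that this assay may again return only a limit.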

Compound 4, distribution coefficient: > 3.7
Compound 4 ended at the assay's limit (the forecaster's own chance of this, stated with the estimate: 65%); the middle value does not contradict the limit.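

Compound 1 and compound 4 both sit at a limit of this assay, so no step between them can be read: the limit of > 3.7 in this assay, at which 2 of the 4 values shown sit.

Going by these compounds, whether ((2,6-difluorophenyl)carbonyl)amino in place of benzylcarbamoyl changes the read-out at all stays open, as does the true position of each compound beyond that limit.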